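A few compounds are considered here, and "the series" means these few. Any claim that something is new, unique, unknown or untested is made for them only; others in the source may bear on it.

Measured so far in a functional assay on MCF7 cells (Homo sapiens) for antiproliferative activity, read by MTT assay, with a stated time of 72 h; a lower number here means a stronger inhibitor, a higher number a weaker inhibitor:
- compound 1 `C=CC(=O)Nc1cccc(Oc2nc(Nc3ccn(C)n3)nc3c2CSCC3)c1` gives > 50000 nM as a limit, not a number
- compound 2 `C=CC(=O)Nc1cccc(Oc2nc(Nc3ccc(OC)cc3)nc3c2CSCC3)c1` gives 11700 nM as the only number

For the measured compounds named here, compound 2 therefore has no numeric neighbour to be ranked against, and its one comparison is with the limit of compound 1.

The next change leads to compound 3 `C=CC(=O)Nc1cccc(Oc2nc(Nc3ccc(OC)nc3)nc3c2CSCC3)c1` and reads 6-methoxypyridin-3-yl in place of 4-methoxyphenyl on a nitrogen on an aromatic ring in the same place, on a nitrogen on an aromatic ring. Going by the values given here, only one measured step bears on it, an at least 4.2-fold lower number from compound 1 to compound 2 (0.63 log units; beyond the scatter) at this same nitrogen, and its true size stays open since one end is a limit. That step involved a different ring swap, so it sets no firm size here. No step beyond the scatter is expected in this assay, with a slight lean towards a higher number. The expected change is a 1.3-fold higher number from compound 2 to compound 3 (0.11 log units; within the scatter) in this estimate. For compound 3 the estimated value is 15000 nM with an expected range of 6000 nM to 40000 nM in this assay.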

Compound 3, half-maximal inhibitory concentration: 17200 nM
For compound 3 the middle estimate is 1.1-fold (0.06 log units) below the measured one; measured number inside the range.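

In this assay, the step from 4-methoxyphenyl to 6-methoxypyridin-3-yl on the nitrogen on an aromatic ring is a 1.5-fold higher number from compound 2 to compound 3 (0.17 log units; within the scatter), so placing a ring nitrogen in the methoxy-bearing six-membered ring gives no readable change. With 6-methoxypyridin-3-yl in place of 1-methyl-1H-pyrazol-3-yl, the series shows an at least 2.9-fold lower number from compound 1 to compound 3 (0.46 log units; beyond the scatter), so a second six-membered aromatic ring also gives a step beyond the scatter. Compound 1 carries a limit, not a number, which leaves the true size of that step open: the limit of > 50000 nM in this assay, at which 1 of the 3 values shown sits.

The compounds shown leave open how this position responds to a different substituent on the six-membered ring, such as an amine or a carboxylic acid, or a longer chain in place of methoxy. They also leave open whether any such group gives a number well below those of compound 2 and compound 3.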